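The source may report more compounds than this note shows. Statements on the series, on what has been measured and on what is new or still open speak of the compounds shown alone.

The three measured compounds are compound 1 `CCN(Cc1cccn1C)C(=O)COc1ccc(C)cc1`, compound 2 `Cc1ccc(OCC(=O)N(Cc2cccs2)CC(C)C)cc1` and compound 3 `Cc1ccc(OCC(=O)N(Cc2cccs2)c2ccn[nH]2)cc1`. In an assay on HEK293 cells for agonist activity at transient receptor potential cation channel subfamily M member 8 (Homo sapiens), read by fluorescence and calcium flux, with a stated time of 15 min (a lower number here means that less compound is needed, a higher number that more compound is needed for the effect), compound 1 gives 21300 nM, the highest of the three numbers; compound 2 gives 900 nM and compound 3 gives 0.2 nM. For the measured compounds named here, the only single-point step among them, a 4500-fold lower number from compound 2 to compound 3 (3.65 log units; beyond the scatter), concerns a group on an amide-type nitrogen. Compound 4 `CCN(Cc1c[nH]nn1)C(=O)COc1ccc(C)cc1` differs from compound 1 by 1H-1,2,3-triazol-4-yl in place of 1-methyl-1H-pyrrol-2-yl on a saturated chain carbon bound to an amide-type nitrogen. That change sits on a saturated chain carbon bound to the amide-type nitrogen rather than on the nitrogen itself, so the step from compound 2 to compound 3 bears on it only loosely, though both changes bring in a five-membered aromatic ring carrying a hydrogen-bond donor. A moderate decrease is therefore expected, a 3.0-fold lower number from compound 1 to compound 4 (0.48 log units; beyond the scatter). Compound 4 is estimated at 7000 nM, with a range from 1000 nM to 50000 nM.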

Compound 4, half-maximal effective concentration: 31100 nM
Compound 4: the middle estimate sits 4.4-fold (0.65 log units) below what was measured, and the stated range covers the measured number.
By their numbers in this assay, from the lowest: compound 3; then compound 2; then compounds 1 and 4 (each within the scatter of the next).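

On the saturated chain carbon bound to the amide-type nitrogen, 1H-1,2,3-triazol-4-yl in place of 1-methyl-1H-pyrrol-2-yl gives a 1.5-fold higher number from compound 1 to compound 4 (0.16 log units; within the scatter) and so leaves the number within the scatter, although the entering five-membered aromatic ring brings a hydrogen-bond donor. For the compounds shown here, the large step of a 4500-fold lower number from compound 2 to compound 3 (3.65 log units; beyond the scatter) on the nitrogen itself has no counterpart at this position. No evidence at hand accounts for this result. The compounds shown leave open whether an amine or a carboxylic acid at this place would shift the number, and whether 1H-1,2,3-triazol-4-yl would give the same outcome with the nitrogen groups of compound 2 or compound 3.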